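The source may hold more compounds than are shown below. What is called first, only, known or untested is meant among the compounds shown, and "the series" means these compounds.

Measured in an ADME assay on HepG2 cells (Homo sapiens) for cytotoxicity, with a stated time of 72 h; a higher number here means that more compound is needed for the effect, a lower number that less compound is needed:
- compound 1 `O=C(Nc1cccc(-c2nc3ccccc3s2)c1)c1cc([N+](=O)[O-])c(O)cc1Cl`: > 25000 nM, a limit
- compound 2 `O=C(Nc1cccc(-c2nc3ccccc3s2)c1)c1cc([N+](=O)[O-])ccc1Cl`: > 27000 nM, a limit

Compound 2 stands only at a limit, with no number read: the limit of > 27000 nM in this assay, at which 1 of the 2 values shown sits. Compound 3 `COc1cc(Cl)c(C(=O)Nc2cccc(-c3nc4ccccc4s3)c2)cc1[N+](=O)[O-]` has methoxy in place of hydrogen on an aromatic carbon, ortho to a nitro group (methoxy in place of hydrogen on an aromatic carbon). Within the data shown here, the one measured step that bears on this is a step that the two limits leave unreadable from compound 1 to compound 2, hydrogen in place of hydroxy on an aromatic carbon, and it gives no readable size. In this assay the expected step is an at least 1.0-fold lower number from compound 2 to compound 3 (0.01 log units; that floor lies within the scatter), with none expected beyond the scatter. The estimate for compound 3 is 26000 nM, ranging from 12000 nM to 40000 nM, and a report as a limit is likely.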

Compound 3, half-maximal effective concentration: > 25000 nM
Compound 3 was reported as a limit (the forecaster's own chance of this, stated with the estimate: 85%); the middle value lies beyond the limit too.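

In this assay, among these compounds, compound 1, compound 2 and compound 3 all stand only at limits, and no step among them can be read. The compounds shown leave open where any true half-maximal effective concentration lies, and whether hydrogen, hydroxy or methoxy changes it.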